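The source may hold more compounds than are shown below. What is called first, only, known or untested is meant among the compounds shown, and "the series" means these compounds.

Compound 1 `COc1ccc2[nH]c(C(=O)Cc3cccnc3)cc2c1` and compound 2 `O=C(Cc1cccnc1)c1cc2cc(Br)ccc2[nH]1` share one core and differ only in the substituent on one aromatic carbon. In an assay on isolated protein for inhibition of Indoleamine 2,3-dioxygenase 1 (Homo sapiens), read by spectrophotometry (on this read-out higher numbers stand for weaker inhibition and lower numbers for stronger inhibition), compound 1 gives 49000 nM, while compound 2 gives 18000 nM. For the measured compounds named here, compound 2 thus holds the lowest of the two numbers seen so far, with compound 1 as its only and nearest neighbour.

Compound 3 `O=C(Cc1cccnc1)c1cc2cc(OC(F)(F)F)ccc2[nH]1` follows from compound 2 by trifluoromethoxy in place of bromo on an aromatic carbon. Going by the values given here, no measured step covers this exchange; the only step that bears on the position, a 2.7-fold lower number from compound 1 to compound 2 (0.43 log units; beyond the scatter), shows that swapping the substituent there moved the number modestly. A change of comparable or smaller size is expected for compound 3, in either direction, most likely not beyond the scatter. Compound 3 is therefore estimated at 20000 nM in this assay, within 8000 nM to 50000 nM. The expected step of a 1.1-fold higher number from compound 2 to compound 3 (0.05 log units; within the scatter) is small.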

Compound 3, half-maximal inhibitory concentration: 13100 nM
Compound 3: middle estimate off by 1.5-fold (0.18 log units), on the high side, within the range that was stated.
By their numbers in this assay, from the lowest: compounds 3 and 2 (each within the scatter of the next); then compound 1.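

At this position in this assay, bromo and trifluoromethoxy are not separated: a 1.4-fold lower number from compound 2 to compound 3 (0.14 log units; within the scatter), although the entering group has 5 heavy atoms and 1 hydrogen-bond acceptor, against 1 heavy atom and no acceptor for bromo. Trifluoromethyl in place of methyl on the oxygen gives a 3.7-fold lower number from compound 1 to compound 3 (0.57 log units; beyond the scatter), so methoxy now stands apart from two other substituents, with compound 1 carrying the higher number in both comparisons. No measurement on hand accounts for either step.

Still open, on these data alone, is how an amine, a carboxylic acid or a longer alkoxy chain would read on this aromatic carbon. Also open, as far as these compounds go, is whether the exchange of bromo for trifluoromethoxy would stay within the scatter on other aromatic carbons of the shared core.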